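Chloro to hydrogen beside the acid: one step

A few compounds are considered here, and "the series" means these few. Any claim that something is new, unique, unknown or untested is made for them only; others in the source may bear on it.

Measured compounds:
compound 2 `Cc1c(OCCCCOc2ccc(C(=O)O)c(Cl)c2)ccc(C(=O)CC(C)C)c1O` — 2050 nM
compound 1 `Cc1c(OCCCCOc2ccccc2C(=O)O)ccc(C(=O)CC(C)C)c1O` — "not determined" (no result reported)

Within the data shown here, in an assay on HEK293 cells for positive allosteric modulation of metabotropic glutamate receptor 3 (Rattus norvegicus), read by thallium flux, with a stated time of 2.5 min (a lower number here means that less compound is needed, a higher number that more compound is needed for the effect), compound 2 gives 2050 nM, the only number in hand; compound 1 gives "not determined" (no result reported). Compound 3 `Cc1c(OCCCCOc2ccc(C(=O)O)cc2)ccc(C(=O)CC(C)C)c1O` differs from compound 2 by hydrogen in place of chloro on an aromatic carbon. Among the measured compounds shown here, no measured step covers such a change, so the direction rests on nothing firm. The step is expected to be small, with loss at least as likely as gain, and a 1.5-fold higher number from compound 2 to compound 3 (0.17 log units; within the scatter) is the estimated outcome. Compound 3 is therefore expected at 3000 nM in this assay, between 900 nM and 10000 nM.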

Compound 3, half-maximal effective concentration: 2720 nM
Compound 3: middle estimate off by 1.1-fold (0.04 log units), on the high side; the range from low to high includes it.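

In this assay the change from chloro to hydrogen on the aromatic carbon ortho to the carboxy group now has a measured size (a 1.3-fold higher number from compound 2 to compound 3 (0.12 log units; within the scatter)), which lies within the scatter. At this position, then, the chloro group can be lost without a change that can be told from repeat measurements. Nothing on hand accounts for this result. Still open, going by these compounds, is how a fluoro, methoxy or amino group would read on this same carbon. Also open, on these data alone, is whether a carboxamide could stand in for the carboxy group.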